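This account rests on a few compounds, and the source may have more. Where it says the series, first, only, none or still open, it means among the compounds named here.

Two members of the series have been run in an ADME assay for permeability, using PAMPA, with a stated time of 18 h; a higher number here means that the compound crosses the layer faster, a lower number that the compound crosses the layer more slowly. Compound 1 `CCS(=O)(=O)N1CC(Oc2cncc(N3C(=O)c4ccc(Cl)cc4C3(C)C)c2)C1` gives 4.17 10^-6 cm/s, the higher of the two numbers, although compound 2 `Cn1cc(C(=O)N2CC3(C2)CN(c2cncc(N4C(=O)c5ccc(Cl)cc5C4(C)C)c2)C3)cn1`, which gives 3.63 10^-6 cm/s, lies within the scatter of it, so no order between them is claimed. Compound 3 `Cn1cc(C(=O)N2CC(Oc3cncc(N4C(=O)c5ccc(Cl)cc5C4(C)C)c3)C2)cn1` is not yet measured; it differs from compound 1 in one place: (1-methyl-1H-pyrazol-4-yl)carbonyl in place of ethylsulfonyl on an amine nitrogen in a ring. Going by the values given here, no step between measured compounds is known. Since compound 2 carries the same entering group and gives 3.63 10^-6 cm/s, the step of a 1.2-fold lower number from compound 1 to compound 3 (0.08 log units; within the scatter) is expected to stay within the scatter, with no clear direction. For compound 3 a value of 3.5 10^-6 cm/s is estimated, in the range 2 10^-6 cm/s to 6 10^-6 cm/s.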

Compound 3, apparent permeability: 3.45 10^-6 cm/s
Compound 3: middle estimate off by 1.0-fold (0.01 log units), on the high side, within the range that was stated.
By their numbers in this assay, from the lowest: compounds 3, 2 and 1 (each within the scatter of the next).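

At this position, on an amine nitrogen in a ring, (1-methyl-1H-pyrazol-4-yl)carbonyl in place of ethylsulfonyl now gives a directly read step in this assay (a 1.2-fold lower number from compound 1 to compound 3 (0.08 log units; within the scatter)). This exchange of a group with no ring for one with a five-membered aromatic ring therefore stays within the scatter on this core. No measurement on hand accounts for this result.

Going by these compounds, whether a carboxylic acid or a longer chain on this nitrogen would give a step beyond the scatter remains open. One step also cannot show whether the same exchange behaves alike on another core.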